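The compounds below may be only part of what the source reports. "The series", "measured", "known", "first", "only" and "open" are said of these compounds alone.

Measured compounds:

Compound 1, `Clc1cc(Cl)cc(CO[C@H]2CCCN(Cc3ncco3)[C@H]2c2ccccc2)c1`. In an assay on isolated protein for activation of cGMP-dependent protein kinase 1 (Homo sapiens), read by ADP-Glo, with stated times of 120 min and 40 min (a lower number here means that less compound is needed, a higher number that more compound is needed for the effect), compound 1 reaches only a limit of the assay, > 200000 nM.

Compound 2, `Clc1cc(Cl)cc(CO[C@H]2CCCN(Cc3ccc(-c4nn[nH]n4)cc3)[C@H]2c2ccccc2)c1`. In this assay compound 2 gives 74000 nM.

Compound 3, `O=C(O)c1ccc(CN2CCC[C@H](O[C@H](CO)c3cc(Cl)cc(Cl)c3)[C@@H]2c2ccccc2)cc1`. In this assay compound 3 gives 11000 nM.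

Of the two actual numbers shown, compound 3 has the lower one, and its gap to compound 2 is beyond the scatter. Compound 1 stands at a limit rather than a number, (the limit of > 200000 nM in this assay, at which 1 of the 3 values shown sits). Among the measured compounds shown here, the only measured step, an at least 2.7-fold lower number from compound 1 to compound 2 (0.43 log units; beyond the scatter), concerns the group carried on the amine nitrogen of the ring, which is not the part altered in the step considered here.

Compound 4, `O=C(O)c1ccc(CN2CCC[C@H](OCc3cc(Cl)cc(Cl)c3)[C@@H]2c2ccccc2)cc1`, differs from compound 3 by hydrogen in place of hydroxymethyl on a saturated chain carbon bound to an aromatic carbon and an oxygen on a saturated carbon. For the measured compounds named here, no measured step touches this position, so the expectation rests on the value of compound 3 alone, and a small group is removed. The step from compound 3 to compound 4 is expected to be a 1.3-fold higher number from compound 3 to compound 4 (0.10 log units; within the scatter), not beyond the scatter in either direction. Compound 4 is therefore estimated to give 14000 nM in this assay, with a range from 5000 nM to 45000 nM.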

Compound 4, half-maximal effective concentration: 76000 nM
The estimate for compound 4 lay 5.4-fold (0.73 log units) below the measured number; the measured number lies above the stated range.
By their numbers in this assay, from the lowest: compound 3; then compounds 2 and 4 (each within the scatter of the next). At a limit, above all of these: compound 1.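

Going from 1-(3,5-dichlorophenyl)-2-hydroxyethyl to 3,5-dichlorobenzyl gives a 6.9-fold higher number from compound 3 to compound 4 (0.84 log units; beyond the scatter) in this assay, so this saturated chain carbon is a place where the change can be read, which no earlier step showed. Without the hydroxymethyl, carboxy in place of 2H-tetrazol-5-yl on an aromatic carbon gives a 1.0-fold higher number from compound 2 to compound 4 (0.01 log units; within the scatter), so these two groups cannot be told apart here. Compound 1 stands at a limit and not at a number, which leaves the step of an at least 2.6-fold lower number from compound 1 to compound 4 (0.42 log units; beyond the scatter) as only a bound on its size.

The data shown offer no measured reason for the change at the hydroxymethyl position. On these data alone, it stays open whether a methyl, a methoxymethyl or an aminomethyl group on this carbon would give a number like that of compound 3 or like that of compound 4.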